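Swapping an Aryl Ether for a Fluoropyridine in Compound 1

The source may hold more compounds than are shown below. What is called first, only, known or untested is meant among the compounds shown, and "the series" means these compounds.

Compound 1 (`O=C1CC(Oc2ncccn2)CN1c1cnn2c1CN(C(=O)Nc1cc(F)c(F)c(F)c1)C(C1CC1)C2`) was tested in a toxicity assay on HepG2 2.2.15 cells (Homo sapiens) for cytotoxicity, read by CellTiter-Glo (a higher number here means that more compound is tolerated, a lower number that less compound is tolerated), where compound 1 gives only a limit, > 200000 nM. Two related compounds were run the same way. Compound 2 (`O=C(Nc1cc(F)c(F)c(F)c1)N1CCCn2ncc(N3CC(c4ccccc4)CC3=O)c2C1`) also returns a limit, > 2000 nM. Compound 3 (`C[C@H]1Cn2ncc(N3CC(c4ccccc4)CC3=O)c2CN1C(=O)NCc1cc(F)c(F)c(F)c1`) likewise returns a limit, > 2000 nM. Going by the values given here, since none of the three values is a number, no step between measured compounds can be read; compound 1 sits at the limit of > 200000 nM in this assay, at which 1 of the 3 values shown sits, the other two at the limit of > 2000 nM in this assay, at which 2 of the 3 values shown sit. Compound 4 (`O=C1CC(c2ccc(F)cn2)CN1c1cnn2c1CN(C(=O)Nc1cc(F)c(F)c(F)c1)C(C1CC1)C2`) differs from compound 1 in one place: 5-fluoropyridin-2-yl in place of (pyrimidin-2-yl)oxy on a saturated ring carbon. Among the compounds with values here, with no measured step to lean on, the expectation for compound 4 in this assay is no change beyond the scatter, a step of a number no higher from compound 1 to compound 4 (the limit leaves the size open). Compound 4 is therefore estimated at 200000 nM, within 50000 nM to 400000 nM, most likely again reported only as a limit.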

Compound 4, half-maximal cytotoxic concentration: 38500 nM
Compound 4: the middle estimate sits 5.2-fold (0.72 log units) above what was measured, outside the stated range (below it).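

In this assay, the saturated ring carbon proves sensitive to the group it carries: 5-fluoropyridin-2-yl in place of (pyrimidin-2-yl)oxy gives an at least 5.1-fold lower number from compound 1 to compound 4 (0.71 log units; beyond the scatter). The earlier compounds shown here, which gave only limits, could show no such difference at this position. The true size of the step stays unknown because compound 1 gives only a limit: the limit of > 200000 nM in this assay, at which 1 of the 4 values shown sits.

Going by these compounds alone, the single swap leaves open which part of it carries the step, the oxygen link, the ring nitrogens or the fluorine. From the compounds shown here alone, how a morpholine or a carboxylic acid on this carbon would read in this assay also remains open.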